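The source may hold more compounds than are shown below. What is called first, only, known or untested is meant among the compounds shown, and "the series" means these compounds.

Measured compounds:
- Compound 1, `COc1cc2ncnc(Nc3cccc(F)c3)c2cc1OCCCCC(=O)Nc1ccc(S(N)(=O)=O)cc1`: in a functional assay on NCI-H1975 cells (Homo sapiens) for antiproliferative activity, read by MTT assay, with a stated time of 72 h (on this read-out lower numbers stand for stronger inhibition and higher numbers for weaker inhibition), compound 1 gives > 40000 nM, which is a limit of the assay rather than a number.
- Compound 2, `COc1cc2ncnc(Nc3ccc(Cl)cc3)c2cc1OCCCCC(=O)Nc1ccc(S(N)(=O)=O)cc1`: in this assay compound 2 gives 31800 nM.

Among the measured compounds shown here, compound 2 thus stands as the only compound with an actual number in this assay, the other value being (the limit of > 40000 nM in this assay, at which 1 of the 2 values shown sits). Compound 3, `COc1ccc(Nc2ncnc3cc(OC)c(OCCCCC(=O)Nc4ccc(S(N)(=O)=O)cc4)cc23)cc1`, differs from compound 2 by methoxy in place of chloro on an aromatic carbon. For the measured compounds named here, the only measured step, an at least 1.2-fold lower number from compound 1 to compound 2 (0.09 log units; that floor lies within the scatter), exchanges one halogenated ring for another on the same nitrogen and does not reach beyond the scatter; no measured step swaps a halogen for a methoxy group, so there is no direct guide for the change to compound 3. The expected step in this assay is therefore a 1.1-fold lower number from compound 2 to compound 3 (0.03 log units; within the scatter), nothing beyond the scatter. Compound 3 is estimated at 30000 nM, within a range of 10000 nM to 90000 nM.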

Compound 3, half-maximal inhibitory concentration: 30200 nM
Compound 3: the middle estimate sits 1.0-fold (0.00 log units) below what was measured; the range from low to high includes it.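

In this assay, chloro and methoxy cannot be told apart on the aromatic carbon para to a large group: the change gives a 1.1-fold lower number from compound 2 to compound 3 (0.02 log units; within the scatter). Among the compounds shown here, this is the first measured exchange of a halogen for a methoxy group here, and the added hydrogen-bond acceptor and extra heavy atom leave the number within the scatter. Replacing 3-fluorophenyl with 4-methoxyphenyl gives an at least 1.3-fold lower number from compound 1 to compound 3 (0.12 log units; that floor lies within the scatter), and no more can be said, as compound 1 carries a limit of the assay and not a number: the limit of > 40000 nM in this assay, at which 1 of the 3 values shown sits.

The compounds shown therefore leave open whether any change on this ring can move the number beyond the scatter. An amine or a carboxylic acid at this place, or a longer chain between the core and the amide, could each test that.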